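The compounds below may be only part of what the source reports. "The series", "measured", "known", "first", "only" and "open" are said of these compounds alone.

Measured so far in a functional assay on K562 cells (Homo sapiens) for cytotoxicity, read by MTT assay, with a stated time of 48 h; a lower number here means a stronger inhibitor, a higher number a weaker inhibitor:

- Compound 1 `COc1ccc(-c2cn(C(=O)Nc3cc(OC)c(OC)c(OC)c3)c(=O)n2-c2cc(OC)c(OC)c(OC)c2)cc1O`: > 50000 nM (a limit)
- Compound 2 `COc1cc(-n2c(-c3ccccc3)cn(C(C)=O)c2=O)cc(OC)c1OC`: > 50000 nM (a limit)

Neither entry is a true number. Compound 2 gives > 50000 nM, which is a limit of this assay. Compound 1 gives > 50000 nM, which is also a limit. The whole picture so far is the limit of > 50000 nM in this assay, at which 2 of the 2 values shown sit. Compound 2 therefore has no exact potency to start from, and the two compounds cannot be ranked against each other.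

The next compound is compound 3 `COc1ccc(-c2cn(C(C)=O)c(=O)n2-c2cc(OC)c(OC)c(OC)c2)cc1OC`, which has not yet been measured. It carries 3,4-dimethoxyphenyl in place of phenyl on an aromatic carbon. The rest of the structure stays the same as in compound 2.

Among the measured compounds shown here, no measured pair shows what this kind of swap does, so any forecast is loose. A modest gain in strength is expected, though compound 3 may well remain at the limit. The expected change is an at least 2.0-fold lower number from compound 2 to compound 3 (0.30 log units; that floor lies within the scatter). The estimated value for compound 3 is 25000 nM, with an expected range from 4000 nM to 50000 nM.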

Compound 3, half-maximal inhibitory concentration: 43400 nM
The estimate for compound 3 lay 1.7-fold (0.24 log units) below the measured number; the measured number falls inside the stated range.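

In this assay, among the compounds shown here, compound 3 gives 43400 nM, the first exact number in this set and so the first firm value from which later changes can be judged. Placing 3,4-dimethoxyphenyl in place of phenyl on this aromatic carbon gives an at least 1.1-fold lower number from compound 2 to compound 3 (0.06 log units; that floor lies within the scatter), and this figure is only a floor, so it shows that a true number was reached but does not fix the size of the step, which may be small or much larger. Compound 2 has only a limit, so the start of this step remains unknown, and most of the set is still held at one boundary: the limit of > 50000 nM in this assay, at which 2 of the 3 values shown sit.

As far as these compounds go, it remains open whether both methoxy groups are needed for compound 3 to give a measurable value, or whether one alone would serve. It is also unknown how an amine or a carboxylic acid on that phenyl ring, or a longer chain in place of the acetyl group, would change the number in this assay.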